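Adding butyl to the chain of compound 1

The source may hold more compounds than are shown below. What is called first, only, known or untested is meant among the compounds shown, and "the series" means these compounds.

- Compound 1 `CCCCCCCCNC[C@@H]1OC[C@H](N)[C@@H]1O` (13800 nM)
- Compound 2 `CCCCCCCCCCCCNC[C@@H]1OC[C@H](N)[C@H]1O` (2380 nM)
- Compound 3 `CCCCCCCCCCCCCCNC[C@@H]1OC[C@H](N)[C@H]1O` (1990 nM)

In a functional assay on PC-3 cells (Homo sapiens) for antiproliferative activity, read by MTT assay, with a stated time of 72 h (on this read-out higher numbers stand for weaker inhibition and lower numbers for stronger inhibition), compound 1 has the highest number of the three, and compounds 2 and 3 both lie lower by more than the usual scatter. Compound 4 `CCCCCCCCCCCCNC[C@@H]1OC[C@H](N)[C@@H]1O` differs from compound 1 by butyl in place of hydrogen on a saturated chain carbon, eight bonds along the chain from an amine nitrogen and keeps the core of compound 1 unchanged.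

For the measured compounds named here, only one measured step compares chain lengths directly: a 1.2-fold lower number from compound 2 to compound 3 (0.08 log units; within the scatter) stays within the scatter and so shows no clear change. It offers little guidance here, since the step to compound 4 starts from a shorter chain. Compound 2 at 2380 nM is the closest guide, with the same chain as compound 4 but a different three-dimensional arrangement at one carbon of the core. Going by the values given here, no measured pair isolates that arrangement, so the range is kept wide. A clear drop is expected, a 4.6-fold lower number from compound 1 to compound 4 (0.66 log units; beyond the scatter) in size. For compound 4 the estimated value is 3000 nM with an expected range of 1300 nM to 7500 nM in this read-out.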

Compound 4, half-maximal inhibitory concentration: 850 nM
For compound 4 the middle estimate is 3.5-fold (0.55 log units) above the measured one; measured number below the stated range.
By their numbers in this assay, from the lowest: compound 4; then compounds 3 and 2 (each within the scatter of the next); then compound 1.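

In this assay, butyl in place of hydrogen on a saturated chain carbon, eight bonds along the chain from an amine nitrogen, gives a 16-fold lower number from compound 1 to compound 4 (1.21 log units; beyond the scatter), so with the core left unchanged, this extension of the chain makes a large difference. For the compounds shown here, the result also gives the first pair that isolates the three-dimensional arrangement of the core, with a modest but real step of a 2.8-fold lower number from compound 2 to compound 4 (0.45 log units; beyond the scatter). That step can be traced to the drawn configuration at a single saturated ring carbon because nothing else separates the pair: the fact that compounds 2 and 4 differ only in the configuration as drawn

Going by these compounds, what remains open is where a decyl chain on the core of compound 1 would fall between these values, which would show how the response builds with chain length. Going by these compounds alone, it is also unknown whether a longer chain, such as the one in compound 3, would change the number further on that same core.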